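Branching the nitrogen-bound chain in the amide series

The source may hold more compounds than are shown below. What is called first, only, known or untested is meant among the compounds shown, and "the series" means these compounds.

Of the compounds shown here, two have been measured in an assay on Prostate gland for inhibition of steroid 5-alpha-reductase (Rattus norvegicus); a higher number here means a weaker inhibitor, a lower number a stronger inhibitor. Compound 1 `CCCCn1ccc2cc(/C(C)=C/C(=O)Nc3ccccc3OCCCC(=O)O)ccc21` gives 43 nM, the lowest of the two numbers. Compound 2 `CC(C)=CCn1ccc2cc(/C(C)=C/C(=O)Nc3ccccc3OCCCC(=O)O)ccc21` gives 120 nM; the step of a 2.8-fold higher number from compound 1 to compound 2 (0.45 log units; beyond the scatter) is the only one measured so far, and it comes from exchanging the chain on the aromatic nitrogen for an unsaturated, branched one.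

Compound 3 `CCCC(CC)n1ccc2cc(/C(C)=C/C(=O)Nc3ccccc3OCCCC(=O)O)ccc21` has not yet been measured in this assay. It differs from compound 1 by ethyl in place of hydrogen on a saturated chain carbon bound to an aromatic nitrogen and a saturated chain carbon, so the chain keeps its saturated character and gains a branch at the carbon bound to the aromatic nitrogen. Within the data shown here, no measured step concerns exactly this change; the step from compound 1 to compound 2 alters the same carbon but in a different way, and its modest size suggests that this position tolerates variation without large swings in either direction. On that basis a small weakening at most is expected, possibly none beyond the scatter, with a 1.6-fold higher number from compound 1 to compound 3 (0.21 log units; within the scatter) as the anticipated step. Compound 3 is therefore estimated at 70 nM, within a range of 25 nM to 200 nM.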

Compound 3, half-maximal inhibitory concentration: 9.3 nM
Beside the measured number, compound 3's estimate is 7.5-fold (0.88 log units) above it; the whole stated range lies above it.
By their numbers in this assay, from the lowest: compound 3; then compound 1; then compound 2.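

In this assay, among these compounds, ethyl in place of hydrogen on a saturated chain carbon bound to an aromatic nitrogen and a saturated chain carbon gives a 4.6-fold lower number from compound 1 to compound 3 (0.66 log units; beyond the scatter), so butyl to 1-ethylbutyl is the first change at this position to lower the number, whereas the only earlier step, a 2.8-fold higher number from compound 1 to compound 2 (0.45 log units; beyond the scatter), raised it. Replacing 3-methylbut-2-en-1-yl with 1-ethylbutyl on the aromatic nitrogen gives a 13-fold lower number from compound 2 to compound 3 (1.11 log units; beyond the scatter), which shows that the nitrogen-bound chain alone can move the number much further than the first pair suggested and places compound 3 lowest of the three, with its steps to both others beyond the scatter. Nothing at hand accounts for this difference between the chains.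

In these compounds, the branch at the nitrogen-bound carbon and the added ethyl arrive together, so the contribution of each remains unresolved; an unbranched hexyl chain on the aromatic nitrogen would bear on that question. Also open, from the compounds shown here alone, is whether the lower number persists with a larger branched chain such as 1-propylbutyl, or with a closed cyclohexyl ring at the same nitrogen.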